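Piperazine methyl and oxime ether homologues: Vero cytotoxicity notes

The source may report more compounds than this note shows. Statements on the series, on what has been measured and on what is new or still open speak of the compounds shown alone.

Compound 1 `CON=C1CCC(CN2CCN(c3nc(=O)c4cc(C(F)(F)F)cc([N+](=O)[O-])c4s3)CC2)CC1` is the parent of this small set. In an ADME assay on Vero cells (Chlorocebus sabaeus) for cytotoxicity (on this read-out lower numbers stand for higher toxicity in this test and higher numbers for lower toxicity in this test), compound 1 gives > 64 ug/mL, which is a limit of the assay and not a number. Compound 2 `CCON=C1CCC(CN2CCN(c3nc(=O)c4cc(C(F)(F)F)cc([N+](=O)[O-])c4s3)CC2)CC1` differs from compound 1 by methyl in place of hydrogen on a saturated chain carbon bound to an oxygen on an unsaturated carbon. In this assay compound 2 gives > 64 ug/mL, again a limit. Compound 3 `CON=C1CCC(CN2CCN(c3nc(=O)c4cc(C(F)(F)F)cc([N+](=O)[O-])c4s3)C[C@@H]2C)CC1` differs from compound 1 by methyl in place of hydrogen on a saturated ring carbon. In this assay compound 3 gives > 64 ug/mL, also a limit. Accordingly the steps a step that the two limits leave unreadable from compound 1 to compound 2 and a step that the two limits leave unreadable from compound 1 to compound 3 cannot be sized; what is shared is the limit of > 64 ug/mL in this assay, at which 3 of the 3 values shown sit.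

Compound 4 `CCON=C1CCC(CN2CCN(c3nc(=O)c4cc(C(F)(F)F)cc([N+](=O)[O-])c4s3)[C@H](C)C2)CC1` is not yet measured. It differs from compound 2 by methyl in place of hydrogen on a saturated ring carbon, the same change already made from compound 1 to compound 3, and the two cores differ by methyl in place of hydrogen on a saturated chain carbon bound to an oxygen on an unsaturated carbon. For this assay the step from compound 2 to compound 4 is expected to be a step that the limit leaves unreadable from compound 2 to compound 4, an expectation resting on the unreadable step that the two limits leave unreadable from compound 1 to compound 3 and on (the limit of > 64 ug/mL in this assay, at which 3 of the 3 values shown sit). Compound 4 is therefore estimated at 80 ug/mL, most likely reported only as a limit, within 40 ug/mL to 160 ug/mL.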

Compound 4, half-maximal cytotoxic concentration: > 64 ug/mL
Compound 4 gave a limit, no number (the forecaster's own chance of this, stated with the estimate: 85%); the middle value lies beyond the limit too.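

In this assay compound 4 gives > 64 ug/mL, which is a limit of the assay and not a number. Among these compounds, compound 2 also stands at a limit, so no step between compound 2 and compound 4 can be read. The compounds shown leave open what cytotoxic concentration any of them would reach as a number, and so how much either methyl change matters.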